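From Methoxy to Methyl on Compound 1

The source may hold more compounds than are shown below. What is called first, only, known or untested is meant among the compounds shown, and "the series" means these compounds.

Measured in a functional assay on KARPAS-422 cells (Homo sapiens) for antiproliferative activity, read by resazurin assay, with a stated time of 72 h; on this read-out higher numbers stand for weaker inhibition and lower numbers for stronger inhibition:
- compound 1 `COc1cc(C)[nH]c(=O)c1CN1CCc2c(Cl)cc(-c3c(C)noc3C)c(Cl)c2C1=O`: 27 nM
- compound 2 `COc1cc(C)[nH]c(=O)c1CN1CCc2c(Cl)cc([C@H](O)C3COC3)c(Cl)c2C1=O`: 108 nM
- compound 3 `COC(c1cc(Cl)c2c(c1Cl)C(=O)N(Cc1c(C)cc(C)[nH]c1=O)CC2)C1CCS(=O)(=O)CC1`: 970 nM; 24 nM (2 entries)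

Compound 1 has the lower of the two single numbers, while compound 3 has no single number. Compound 4 `Cc1cc(C)c(CN2CCc3c(Cl)cc(-c4c(C)noc4C)c(Cl)c3C2=O)c(=O)[nH]1` keeps the rest of compound 1 but has methyl in place of methoxy on an aromatic carbon, opposite the ring nitrogen: methyl in place of methoxy on an aromatic carbon. Among the measured compounds shown here, the one measured step, a 4.0-fold higher number from compound 1 to compound 2 (0.60 log units; beyond the scatter), lies at a different place, so it is only a loose guide to size. Compound 3 also has methyl at this place but differs elsewhere, and the several entries of compound 3 in this assay, 970 nM; 24 nM (2 entries) spread too widely to settle the matter. The expected change is a 1.3-fold higher number from compound 1 to compound 4 (0.11 log units; within the scatter), so no clear step is foreseen in this assay. For compound 4 the estimated value is 35 nM, with an expected range of 11 nM to 110 nM.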

Compound 4, half-maximal inhibitory concentration: 23 nM
Beside the measured number, compound 4's estimate is 1.5-fold (0.18 log units) above it; the range from low to high includes it.
By their numbers in this assay, from the lowest: compounds 4 and 1 (each within the scatter of the next); then compound 2.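

In this assay, replacing methoxy with methyl on this aromatic carbon, opposite the ring nitrogen, gives a 1.2-fold lower number from compound 1 to compound 4 (0.07 log units; within the scatter). With the rest of compound 1 held fixed, the read-out therefore shows no clear step when the oxygen and its hydrogen-bond acceptor are removed. Compound 3 could not show this, since it differs elsewhere and has no single number: the several entries of compound 3 in this assay, 970 nM; 24 nM (2 entries)

Still open, from the compounds shown here alone, is how other groups on this carbon would read in this assay, such as an ethyl group, a chlorine atom or an amine. A bare hydrogen here also remains untested among the compounds shown.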